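A few compounds are considered here, and "the series" means these few. Any claim that something is new, unique, unknown or untested is made for them only; others in the source may bear on it.

Measured so far in an assay on CHO cells for antagonist activity at transient receptor potential cation channel subfamily V member 1 (Homo sapiens), read by FLIPR; a higher number here means a weaker inhibitor, a lower number a stronger inhibitor:

compound 1 `CC1CCN(c2cc(C(F)(F)F)ccc2CNC(=O)C(C)c2ccc(NS(C)(=O)=O)c(F)c2)CC1`, 0.9 nM
compound 2 `CCC1CCN(c2cc(C(F)(F)F)ccc2CNC(=O)C(C)c2ccc(NS(C)(=O)=O)c(F)c2)CC1`, 0.7 nM
compound 3 `CC(C)COc1cc(C(F)(F)F)ccc1CNC(=O)C(C)c1ccc(NS(C)(=O)=O)c(F)c1`, 0.8 nM

Compound 3 sits together with the other two: the step of a 1.1-fold lower number from compound 1 to compound 3 (0.05 log units; within the scatter) and the step of a 1.1-fold higher number from compound 2 to compound 3 (0.06 log units; within the scatter) are both within the scatter, as is a 1.3-fold lower number from compound 1 to compound 2 (0.11 log units; within the scatter).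

Compound 4 `CCCCCCSc1cc(C(F)(F)F)ccc1CNC(=O)C(C)c1ccc(NS(C)(=O)=O)c(F)c1` differs from compound 3 by hexylsulfanyl in place of isobutoxy on an aromatic carbon. The steps that touch the same aromatic carbon, a 1.1-fold lower number from compound 1 to compound 3 (0.05 log units; within the scatter) and a 1.1-fold higher number from compound 2 to compound 3 (0.06 log units; within the scatter), were both within the scatter, so exchanges at this position have so far left this assay unchanged. For the measured compounds named here, no measured step covers a hexylsulfanyl group or a sulfur-linked chain, so the expectation rests on those two steps only.

Compound 4 is therefore expected to give about 1 nM in this assay, with a range of 0.3 nM to 3.5 nM, meaning an expected step of a 1.3-fold higher number from compound 3 to compound 4 (0.10 log units; within the scatter), none beyond the scatter.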

Compound 4, inhibition constant: 1.8 nM
Compound 4: the middle estimate sits 1.8-fold (0.26 log units) below what was measured; the range from low to high includes it.
By their numbers in this assay, from the lowest: compounds 2, 3, 1 and 4 (each within the scatter of the next, the first and the last beyond it).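

Hexylsulfanyl is the first group at this aromatic carbon to shift the number in this assay beyond the scatter, seen in a 2.3-fold higher number from compound 3 to compound 4 (0.35 log units; beyond the scatter) and in a 2.6-fold higher number from compound 2 to compound 4 (0.41 log units; beyond the scatter) as modest steps. Against compound 1 the change stays within the scatter, with a 2.0-fold higher number from compound 1 to compound 4 (0.30 log units; within the scatter) as the printed step, so the position accepts this longer sulfur-linked chain with only a modest shift. No available evidence bears on the reason for this shift.

Hexyloxy and isobutylsulfanyl are absent from the compounds shown, so the linking sulfur and the chain length cannot be separated. An octylsulfanyl chain would show whether the trend continues.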